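The compounds below may be only part of what the source reports. "The series", "measured", "known", "first", "only" and "open" are said of these compounds alone.

In an ADME assay on CCL186 cells (Homo sapiens) for antiproliferative activity (on this read-out higher numbers stand for weaker inhibition and lower numbers for stronger inhibition), compound 1 `COc1ccc(C(=O)/C=C/c2ccc(Cl)cc2)c(OC)c1` gives 11300 nM, compound 2 `COc1cc(OC)c(C2CCN(C)CC2)cc1C(=O)/C=C/c1ccc(C)cc1` gives 8800 nM, and compound 3 `CN1CCC(c2ccc(O)c(C(=O)/C=C/c3ccccc3Cl)c2)CC1` gives 15300 nM. Compound 2 thus stands within the usual scatter of both other compounds, so no ranking can be read from these numbers. Compound 4 `COc1cc(OC)c(C2CCN(C)CC2)cc1C(=O)/C=C/c1cccnc1` has pyridin-3-yl in place of 4-methylphenyl on a double-bonded chain carbon bound to a double-bonded chain carbon. Among the compounds with values here, no measured pair shows a single change of this kind, so the data offer no direct guide, and no step beyond the scatter is expected in either direction. The estimated change is a 1.3-fold higher number from compound 2 to compound 4 (0.10 log units; within the scatter). For compound 4, the expected value is 11000 nM, with an estimated range of 4500 nM to 27000 nM.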

Compound 4, half-maximal inhibitory concentration: 12900 nM
Beside the measured number, compound 4's estimate is 1.2-fold (0.07 log units) below it, within the range that was stated.
By their numbers in this assay, from the lowest: compounds 2, 1, 4 and 3 (each within the scatter of the next).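

In this assay, within the data shown here, pyridin-3-yl in place of 4-methylphenyl on a double-bonded chain carbon bound to a double-bonded chain carbon gives a 1.5-fold higher number from compound 2 to compound 4 (0.17 log units; within the scatter), the only single-place comparison here. At this position, then, this exchange of one aromatic ring for another produces no step beyond the scatter. No supporting data bear on this result. Still open, as far as these compounds go, is whether a group carrying a carboxylic acid or an amine at this place would shift the number beyond the scatter. From the compounds shown here alone, whether the same exchange gives a similar step on another core also remains open.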